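This account rests on a few compounds, and the source may have more. Where it says the series, first, only, none or still open, it means among the compounds named here.

Compound 1 `O=C(NC/C=C\Cn1ccc(=O)[nH]c1=O)c1ccccc1` and compound 2 `Cc1cn(C/C=C\CNC(=O)c2ccccc2)c(=O)[nH]c1=O` share one core and differ by a single methyl group. In a functional assay on SW-620 cells (Homo sapiens) for cytotoxicity, read by MTT assay, with a stated time of 72 h (on this read-out lower numbers stand for stronger inhibition and higher numbers for weaker inhibition), compound 1 reaches only a limit, > 100000 nM. Compound 2 also reaches only a limit, > 100000 nM, in this assay. The step that the two limits leave unreadable from compound 1 to compound 2 cannot be sized because both values sit at the limit of > 100000 nM in this assay, at which 2 of the 2 values shown sit. Compound 3 `O=C(NC/C=C\Cn1cc(C(F)(F)F)c(=O)[nH]c1=O)c1ccccc1` carries trifluoromethyl in place of methyl on an aromatic carbon. Among the compounds with values here, no measured step gives a size for this kind of change, so the step that the limit leaves unreadable from compound 2 to compound 3 is expected to stay near nothing. Compound 3 is therefore estimated at 150000 nM, between 30000 nM and 600000 nM.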

Compound 3, half-maximal inhibitory concentration: > 100000 nM
Compound 3 ended at the assay's limit; the forecaster's own chance of this, stated with the estimate: 80%; the middle value lies beyond the limit too.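

Within the data shown here, no step among compound 1, compound 2 and compound 3 can be read in this assay, because all three values are limits: the limit of > 100000 nM in this assay, at which 3 of the 3 values shown sit. The compounds shown leave open whether hydrogen, methyl or trifluoromethyl on that aromatic carbon differ at all in this assay.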